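Swapping an octyl chain for a tolyl ring on a thiophene

The compounds below may be only part of what the source reports. "The series", "measured", "known", "first", "only" and "open" are said of these compounds alone.

Measured so far:
Compound 1, `CCCCCCCCc1c(-c2ccccc2)sc(C(C)C)c1/C=C/[C@@H](O)C[C@@H](O)CC(=O)O` — in an assay on microsomes for inhibition of 3-hydroxy-3-methylglutaryl-coenzyme A reductase (Rattus norvegicus) (a higher number here means a weaker inhibitor, a lower number a stronger inhibitor), compound 1 gives > 10000 nM, which is a limit of the assay rather than a number.
Compound 2, `CCCCCCCCc1sc(C(C)C)c(/C=C/[C@@H](O)C[C@@H](O)CC(=O)O)c1-c1ccc(F)cc1` — in this assay compound 2 gives > 10000 nM, again a limit of the assay rather than a number.

Both values sit at the limit of > 10000 nM in this assay, at which 2 of the 2 values shown sit, so compound 2 stands nowhere on a scale of numbers: it is only known to be a weak inhibitor, without a measured value. Within the data shown here, no step between two measured compounds is available, so no measured size of change can guide what comes next.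

Compound 3, `Cc1ccc(-c2sc(C(C)C)c(/C=C/[C@@H](O)C[C@@H](O)CC(=O)O)c2-c2ccc(F)cc2)cc1`, is the untested compound. It differs from compound 2 by 4-methylphenyl in place of octyl on an aromatic carbon. Among the measured compounds shown here, with no measured step to lean on, the expectation is for a gain in potency in this assay of uncertain size, and the estimated step from compound 2 to compound 3 is an at least 5.0-fold lower number from compound 2 to compound 3 (0.69 log units; beyond the scatter). For compound 3 the estimate in this assay is 2000 nM, with a range from 200 nM to 10000 nM.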

Compound 3, half-maximal inhibitory concentration: 9.7 nM
Compound 3: the middle estimate sits 210-fold (2.31 log units) above what was measured; the whole stated range lies above it.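

Compound 2 gives > 10000 nM in this assay, which is a limit of the assay and not a number. Putting 4-methylphenyl in place of octyl on the aromatic carbon next to the ring sulfur gives an at least 1000-fold lower number from compound 2 to compound 3 (3.01 log units; beyond the scatter), so this position can carry a group that yields a measurable inhibitor, and the choice of group here can decide whether a compound registers at all. The true size of this step stays unknown, since it starts from a limit, and it is also the first step that could be read at all: the limit of > 10000 nM in this assay, at which 2 of the 3 values shown sit.

On these data alone, whether the gain comes from the aromatic ring itself or needs its methyl group remains open. So does how a shorter chain such as butyl, or a pyridine ring, would behave on this same carbon.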